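The compounds below may be only part of what the source reports. "The series", "measured", "known", "first", "only" and "open" are said of these compounds alone.

In an ADME assay on HEK293 cells (Homo sapiens) for cytotoxicity, read by MTT assay (on this read-out higher numbers stand for weaker inhibition and lower numbers for stronger inhibition), compound 1 `COc1cc2ncnc(Nc3cc(O)[nH]n3)c2cc1OC` gives 69500 nM. Compound 3 `COc1cc2ncnc(Nc3cc(-c4ccc(Cl)cc4)[nH]n3)c2cc1OC` gives 81200 nM, and the comparison between them is a 1.2-fold higher number from compound 1 to compound 3 (0.07 log units; within the scatter). Compound 2 `COc1cc2ncnc(Nc3cc(-c4ccc(F)cc4)[nH]n3)c2cc1OC` is reported only as a limit, < 100000 nM. Going by the values given here, compound 1 therefore sits level with compound 3, within the scatter, and these are the only two true numbers.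

Compound 4 `COc1ccc(-c2cc(Nc3ncnc4cc(OC)c(OC)cc34)n[nH]2)cc1` differs from compound 1 as follows: 4-methoxyphenyl in place of hydroxy on an aromatic carbon. In words, 4-methoxyphenyl stands in place of hydroxy on an aromatic carbon. Two measured exchanges at the same place bear on this change. Among the compounds with values here, the exchange for 4-chlorophenyl is a 1.2-fold higher number from compound 1 to compound 3 (0.07 log units; within the scatter), which is the only readable guide. The exchange for 4-fluorophenyl is a step that the limit leaves unreadable from compound 1 to compound 2, so it adds no size. On that basis, no change beyond the scatter is expected, and the expected step is a 1.1-fold higher number from compound 1 to compound 4 (0.03 log units; within the scatter). The estimated value for compound 4 is 75000 nM, with an expected range from 35000 nM to 130000 nM.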

Compound 4, half-maximal inhibitory concentration: < 100000 nM
Compound 4 was reported as a limit (the forecaster's own chance of this, stated with the estimate: 35%); the middle value is on the limit's open side.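

In this assay compound 4 is reported only as a limit, < 100000 nM. Its steps from compound 1, compound 2 and compound 3 therefore cannot be read. The compounds shown leave open where compound 2 and compound 4 truly stand relative to compound 1 and compound 3.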